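This account rests on a few compounds, and the source may have more. Where it says the series, first, only, none or still open, it means among the compounds named here.

Series notes, growth inhibition in a functional assay on MIA PaCa-2 cells (Homo sapiens) for inhibition, read by MTT assay, with a stated time of 72 h; on this read-out higher numbers stand for weaker inhibition of growth and lower numbers for stronger inhibition of growth:

- compound 1 `CC(C)c1ccc(S(=O)(=O)NCCCCCCNCc2ccc(Br)cc2)cc1`: 5730 nM
- compound 2 `CC(C)(C)c1ccc(S(=O)(=O)NCCCCCCNCc2ccc(Br)cc2)cc1`: 2970 nM
- compound 3 `O=S(=O)(NCCCCCCNCc1ccc(Br)cc1)c1ccccc1Cl`: 13700 nM

Compound 3 gives the highest number of the three, with compound 1 nearest and compound 2 furthest: the step of a 2.4-fold higher number from compound 1 to compound 3 (0.38 log units; beyond the scatter) is modest but beyond the scatter, while the step of a 1.9-fold lower number from compound 1 to compound 2 (0.29 log units; within the scatter) is within it. The shared core is unchanged throughout; only the group on the sulfonyl sulfur varies.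

Compound 4 `Cc1ccc(S(=O)(=O)NCCCCCCNCc2ccc(Br)cc2)cc1` has not been measured. It differs from compound 3 in one place: 4-methylphenyl in place of 2-chlorophenyl on a sulfonyl sulfur. Within the data shown here, the only measured step that bears on this is the exchange from compound 1 to compound 3, where a 4-isopropylphenyl gave way to a 2-chlorophenyl and the number rose by a 2.4-fold higher number from compound 1 to compound 3 (0.38 log units; beyond the scatter). Compound 4 carries a 4-methylphenyl, which resembles the groups of compound 1 and compound 2 more than that of compound 3, so a step back toward the numbers of compound 1 is expected, of about the size seen between compound 1 and compound 3. Among the measured compounds shown here, no measured pair shows what the methyl itself does here, so the range is kept wide.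

Compound 4 is therefore expected to give about 7000 nM in this assay, between 3500 nM and 15000 nM, a move of a 2.0-fold lower number from compound 3 to compound 4 (0.29 log units; within the scatter).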

Compound 4, concentration for 50% growth inhibition: 12300 nM
For compound 4 the middle estimate is 1.8-fold (0.24 log units) below the measured one, and the stated range covers the measured number.
By their numbers in this assay, from the lowest: compounds 2 and 1 (each within the scatter of the next); then compounds 4 and 3 (each within the scatter of the next).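

In this assay, the step from the 2-chlorophenyl to the 4-methylphenyl on the sulfonyl sulfur, a 1.1-fold lower number from compound 3 to compound 4 (0.05 log units; within the scatter), leaves the two compounds inseparable, so the higher numbers at this position are not confined to the 2-chlorophenyl. The alkyl group on the aromatic carbon now has a measured effect in a matched series: methyl in place of isopropyl gives a 2.1-fold higher number from compound 1 to compound 4 (0.33 log units; beyond the scatter), and methyl in place of tert-butyl gives a 4.1-fold higher number from compound 2 to compound 4 (0.62 log units; beyond the scatter), both beyond the scatter, while compound 1 and compound 2 remain within the scatter of each other. Nothing available accounts for these steps.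

The compounds shown leave open whether the unsubstituted phenyl or a 4-chlorophenyl on the sulfonyl sulfur would fall with compound 3 and compound 4 or with compound 1 and compound 2, which would separate the identity of the chlorine-bearing group from its place on the ring. They also leave open how a 4-methoxyphenyl or a 4-carboxyphenyl would read at this position, and whether a longer chain in the shared core would alter the steps seen here.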